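Trimming a Dichlorophenyl Urea to a Monochlorophenyl

The source may hold more compounds than are shown below. What is called first, only, known or untested is meant among the compounds shown, and "the series" means these compounds.

For the measured compounds named here, compound 2 `Nc1n[nH]c2cccc(-c3cccc(NC(=O)Nc4ccc(Cl)cc4Cl)c3)c12` gives 1900 nM in a functional assay on SMMC-7721 cells (Homo sapiens) for inhibition, read by MTT assay, with a stated time of 48 h (a higher number here means a weaker inhibitor, a lower number a stronger inhibitor), the lower of the two numbers so far, while compound 1 `Nc1n[nH]c2cccc(-c3cccc(NC(=O)Nc4ccc(F)c(F)c4)c3)c12` gives 5880 nM, and the step of a 3.1-fold lower number from compound 1 to compound 2 (0.49 log units; beyond the scatter) is the only one measured. Compound 3 `Nc1n[nH]c2cccc(-c3cccc(NC(=O)Nc4cccc(Cl)c4)c3)c12` differs from compound 2 by 3-chlorophenyl in place of 2,4-dichlorophenyl on an amide-type nitrogen. Going by the values given here, no measured step swaps these two groups, so the earlier step gives only indirect guidance, and it involved a different pair of halogenated rings. Compound 3 is therefore expected to give about 3000 nM, between 1200 nM and 8000 nM. The step of a 1.6-fold higher number from compound 2 to compound 3 (0.20 log units; within the scatter) is expected to stay close to the scatter.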

Compound 3, half-maximal inhibitory concentration: 1830 nM
Compound 3: middle estimate off by 1.6-fold (0.21 log units), on the high side; measured number inside the range.
By their numbers in this assay, from the lowest: compounds 3 and 2 (each within the scatter of the next); then compound 1.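

In this assay, 3-chlorophenyl in place of 2,4-dichlorophenyl on the amide-type nitrogen gives a 1.0-fold lower number from compound 2 to compound 3 (0.02 log units; within the scatter), so with these two rings, a second chlorine brings no measurable difference. Against the 3,4-difluorophenyl ring, the single-chlorine ring gives a 3.2-fold lower number from compound 1 to compound 3 (0.51 log units; beyond the scatter), a gap like the one the 2,4-dichlorophenyl ring showed. Nothing available here explains these results. Whether the remaining chlorine matters at all stays open, since a plain phenyl ring is not among the compounds shown. How a methoxy group, an amine or a carboxylic acid on this ring would compare is also unknown.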